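A few compounds are considered here, and "the series" means these few. Any claim that something is new, unique, unknown or untested is made for them only; others in the source may bear on it.

Measured in a functional assay on HeLa cells (Homo sapiens) for inhibition, read by MTT assay, with a stated time of 48 h; on this read-out higher numbers stand for weaker inhibition and lower numbers for stronger inhibition:
- compound 1 `COc1ccc(-c2nc3ccccn3c2Sc2ccccc2)cc1`: > 100000 nM
- compound 2 `c1ccc(Sc2c(-c3cccc4ccccc34)nc3ccccn23)cc1`: 33100 nM

Compound 1 stands at > 100000 nM, which is a limit of the assay and not a number. Compound 3 `Clc1ccc(-c2nc3ccccn3c2Sc2ccccc2)cc1` carries chloro in place of methoxy on an aromatic carbon, para to a large group (chloro in place of methoxy on an aromatic carbon). Among the measured compounds shown here, with compound 2 at 33100 nM as the only number so far in this assay, a readable value is expected. For compound 3 a second limit of the assay remains possible. The expected at least 1.6-fold lower number from compound 1 to compound 3 (0.22 log units; that floor lies within the scatter) is modest and toward stronger inhibition. For compound 3 the estimate is 60000 nM, with an expected range of 25000 nM to 100000 nM.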

Compound 3, half-maximal inhibitory concentration: 62000 nM
Beside the measured number, compound 3's estimate is 1.0-fold (0.01 log units) below it; measured number inside the range.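

With 4-chlorophenyl in place of 4-methoxyphenyl, compound 3 gives 62000 nM in this assay as a readable number at this position. Compound 1 stands at > 100000 nM as a limit of the assay and not a number. The change reads only as an at least 1.6-fold lower number from compound 1 to compound 3 (0.20 log units; that floor lies within the scatter) and no more, its true size staying open because one end is a limit: the limit of > 100000 nM in this assay, at which 1 of the 3 values shown sits.

Going by these compounds, how an amine, a nitrile or a carboxylic acid at this place would read remains open. So does the effect of the same chloro group elsewhere on the shared core.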